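This account rests on a few compounds, and the source may have more. Where it says the series, first, only, none or still open, it means among the compounds named here.

Compound 1, `CCOC(=O)C(CS)NC(=O)/C=C/c1ccccc1`, bears on its amide nitrogen a short chain carrying a thiol and an ethoxycarbonyl group. In a functional assay, with a stated time of 30 min, tested at 100 uM (on this read-out lower numbers stand for a weaker effect and higher numbers for a stronger effect at the one concentration tested), compound 1 gives 42%. Compound 2, `O=C(/C=C/c1ccccc1)NCCS`, differs from compound 1 only by hydrogen in place of ethoxycarbonyl on a saturated chain carbon bound to an amide-type nitrogen and a saturated chain carbon; in this assay compound 2 gives 59%, the step being a number 17 percentage points higher from compound 1 to compound 2 (beyond the scatter). Compound 3, `CCOC(=O)C(CS)NC(=O)/C=C/c1cc(C(C)(C)C)c(O)c(C(C)(C)C)c1`, carries the same chain as compound 1 on a different core; the difference between the two cores is not broken down here. In this assay compound 3 gives 70%, the highest of the three numbers. Compound 4, `CC(C)(C)c1cc(/C=C/C(=O)NCCS)cc(C(C)(C)C)c1O`, is compound 3 after (hydrogen in place of ethoxycarbonyl on a saturated chain carbon bound to an amide-type nitrogen and a saturated chain carbon), the same change that turned compound 1 into compound 2. For compound 4 in this assay a value of 82% is expected, most likely between 68% and 95%. This expected step a number 12 percentage points higher from compound 3 to compound 4 (beyond the scatter) rests on the earlier pair, because a number 17 percentage points higher from compound 1 to compound 2 (beyond the scatter) was seen there, tempered by the room left under the top of the scale.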

Compound 4, a percentage reported as activity, at one concentration (the size of the read-out at that concentration, not a potency): 60%
Compound 4: the middle estimate sits 22 percentage points above what was measured; the whole stated range lies above it.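

In this assay, putting hydrogen in place of ethoxycarbonyl on the core of compound 3 gives a number 10 percentage points lower from compound 3 to compound 4 (within the scatter), so the two compounds cannot be told apart on this read-out. The change therefore does not carry over with the same effect from one core to the other: the same change on two cores in this assay, a number 17 percentage points higher (beyond the scatter) from compound 1 to compound 2 and a number 10 percentage points lower (within the scatter) from compound 3 to compound 4, 27 percentage points apart, beyond the scatter of two such steps. This shows that a step seen on one core cannot simply be added to another in this series, but two pairs do not show why the cores differ or how a further core would behave.

The compounds shown leave open what a carboxylic acid or a primary amide would do in place of ethoxycarbonyl. They also leave open the effect of a longer chain in place of 2-sulfanylethyl.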